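Swapping a Benzyl Ether Tail for a Polyether Chain

This account rests on a few compounds, and the source may have more. Where it says the series, first, only, none or still open, it means among the compounds named here.

Compound 1 `CN1Cc2ccc(OCCc3ccccc3)cc2[C@@H](O)C1` is tested in an ADME assay on Vero cells (Chlorocebus sabaeus) for cytotoxicity, read by sulforhodamine B assay, with a stated time of 72 h (a higher number here means a weaker inhibitor, a lower number a stronger inhibitor), where compound 1 gives > 50000 nM, a limit of the assay and not a number. For the measured compounds named here, compound 2 `CN1Cc2ccc(OCCCN3CCNCC3)cc2[C@@H](O)C1` is the only comparison; in this assay compound 2 gives > 100000 nM, likewise a limit. The step that the two limits leave unreadable from compound 1 to compound 2 therefore cannot be sized. Compound 3 `COCCOCOc1ccc2c(c1)[C@@H](O)CN(C)C2` carries 2-methoxyethoxy in place of benzyl on a saturated chain carbon bound to an oxygen on an aromatic ring. Both measured compounds sit at limits, as the limit of > 100000 nM in this assay, at which 1 of the 2 values shown sits, and the limit of > 50000 nM in this assay, at which 1 of the 2 values shown sits, show, so no direction can be read from them. Compound 3 is therefore expected to stay at a limit, a step that the limit leaves unreadable from compound 1 to compound 3. For compound 3 the estimate is 80000 nM, with a range from 30000 nM to 200000 nM.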

Compound 3, half-maximal inhibitory concentration: > 50000 nM
Compound 3: no number, only a limit (the forecaster's own chance of this, stated with the estimate: 85%); the middle value lies beyond the limit too.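

In this assay, for the compounds shown here, compound 3 gives > 50000 nM, a limit and not a number, so no step from compound 1 to compound 3 can be read. Going by these compounds, the actual values of compound 1, compound 2 and compound 3 remain open.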